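The compounds below may be only part of what the source reports. "The series", "measured", "known", "first", "only" and "open" are said of these compounds alone.

Of the compounds shown here, three of a shared core have been measured. Compound 1 `COc1ccc2cc([C@H](C)c3nnc(SCc4ccccc4)n3-c3ccc(Cl)cc3)ccc2c1` gives 50400 nM in a functional assay on LNCaP cells (Homo sapiens) for cytotoxicity, read by MTT assay; on this read-out higher numbers stand for weaker inhibition and lower numbers for stronger inhibition. Compound 2 `COc1ccc(CSc2nnc([C@@H](C)c3ccc4cc(OC)ccc4c3)n2-c2ccc(F)cc2)cc1` gives 22800 nM in this assay, and compound 3 `COc1ccc2cc([C@H](C)c3nnc(SCc4c(Cl)cccc4Cl)n3-c3cccc(Cl)c3)ccc2c1` gives 73700 nM in this assay. Compound 2 therefore holds the lowest number of the three and so is the strongest inhibitor: compound 1 lies beyond the scatter above it, and compound 3 lies further still.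

The next compound, compound 4 `COc1ccc2cc([C@H](C)c3nnc(SCc4c(C)cc(C)cc4C)n3-c3ccc(F)cc3)ccc2c1`, has not yet been measured in this assay. It differs from compound 2 in one place: 2,4,6-trimethylphenyl in place of 4-methoxyphenyl on a saturated chain carbon bound to a sulfur.

Going by the values given here, no measured pair shows this exact change, so the size of the step is uncertain. The three measured compounds vary in what hangs on the sulfur and on the core, and the only one carrying a crowded benzyl group, compound 3, gives the highest number. A modest rise in the number, close to the edge of the scatter, is expected from compound 2 to compound 4 a 1.7-fold higher number from compound 2 to compound 4 (0.22 log units; within the scatter). Compound 4 is estimated at 38000 nM, within a range from 15000 nM to 95000 nM.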

Compound 4, half-maximal inhibitory concentration: 2210 nM
Estimate against measurement, compound 4: 17-fold (1.24 log units) above; the measured number lies below the stated range.
By their numbers in this assay, from the lowest: compound 4; then compound 2; then compounds 1 and 3 (each within the scatter of the next).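

Putting 2,4,6-trimethylphenyl in place of 4-methoxyphenyl on a saturated chain carbon bound to a sulfur brings a 10-fold lower number from compound 2 to compound 4 (1.01 log units; beyond the scatter) in this assay, a large step beyond the scatter. Going by these compounds alone, the earlier compounds each differed in more than one place, so only this pair shows that a change at this carbon alone can shift the number so strongly, here with a group that has no hydrogen-bond acceptor replacing one that has one. Nothing measured here explains the size of the step.

The compounds shown leave open whether all three methyl groups are needed or whether a phenyl with a single methyl would give a similar number. They also leave open how a group of another kind on this carbon, such as an amine or a carboxylic acid, would compare.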